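The compounds below may be only part of what the source reports. "The series", "measured", "known", "first", "only" and "open" are said of these compounds alone.

Compound 1 `N=C(N)NCCC[C@H](NC(=O)CN(c1nc(Cl)nc2[nH]cnc12)C1CC1)C(=O)O` was tested in a functional assay on the whole organism (Tail, strain ICR) with Mus musculus as the target, in the tail flick test, with a stated time of 90 min, at a dose of 25 umol/kg by the oral route (on this read-out higher numbers stand for a stronger effect at the one dose given and lower numbers for a weaker effect), and gave 27.6%. Among the three measured compounds its number sits between those of compound 2 `O=C(CN(c1ncnc2c1ncn2C1CCCCO1)C1CC1)N[C@@H](CCC(=O)OCc1ccccc1)C(=O)OCc1ccccc1`, which gave 25.2%, and compound 3 `N=C(N)NCCC[C@H](NC(=O)CN(c1nc(Cl)nc2[nH]cnc12)C1CC1)C(=O)OCc1ccccc1`, which gave 30.4%; all three differences lie within the usual scatter. Among the compounds with values here, the one step measured in a single place, a number 2.8 percentage points higher from compound 1 to compound 3 (within the scatter), concerns a benzyl in place of hydrogen on an oxygen next to a carbonyl group. Compound 4 `O=C(CN(c1nc(Cl)nc2[nH]cnc12)C1CC1)N[C@@H](CO)C(=O)O` differs from compound 1 by one oxygen atom in place of a group of 6 heavy atoms (3 carbon, 3 nitrogen; no ring), on a saturated chain carbon, two bonds along the chain from an amide-type nitrogen and a carbonyl carbon. Within the data shown here, no measured step bears on this change, and the benzyl step touches another part of the molecule. Compound 4 is therefore expected to show a step of a number 5.6 percentage points lower from compound 1 to compound 4 (within the scatter), with no firm direction. The estimate for compound 4 is 22%, between 6% and 38%.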

Compound 4, a percentage reported as activity, at one dose (the size of the read-out at that dose, not a potency): 43.9%
Estimate against measurement, compound 4: 21.9 percentage points below; measured number above the stated range.
By their numbers in this assay, from the lowest: compounds 2, 1 and 3 (each within the scatter of the next); then compound 4.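

In this assay, the hydroxy group on this saturated chain carbon gives a number 16.3 percentage points higher from compound 1 to compound 4 (beyond the scatter), the only step shown that lies beyond the scatter. The group of 6 heavy atoms carried by compound 1 is therefore not required for activity at this dose, and this position affects the read-out in a way the benzyl step elsewhere in the molecule did not show. No available evidence accounts for this step. The compounds shown leave open whether the hydroxy group itself matters, which a methyl or an amine at this position would test, and whether benzyl on the oxygen next to the carbonyl group would change compound 4.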